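This account rests on a few compounds, and the source may have more. Where it says the series, first, only, none or still open, it means among the compounds named here.

Compound 1, `O=c1c2sc(-c3ccc(Cl)cc3)cc2ncn1-c1ccc2c(c1)CCC(CN1CCCCC1)=C2`: 0.75 nM
Compound 2, `O=c1c2sc(-c3ccc(Cl)cc3)cc2ncn1-c1ccc2c(c1)CCC(CN1CCCC1)C2`: 1.3 nM
Compound 3, `O=c1c2sc(-c3ccc(Cl)cc3)cc2ncn1-c1ccc2sc(CN3CCCC3)cc2c1`: 0.91 nM

All three were measured in a functional assay on CHO cells for antagonist activity at melanin-concentrating hormone receptor 1 (Homo sapiens), read by reporter gene assay; on this read-out higher numbers stand for weaker inhibition and lower numbers for stronger inhibition. Compound 3 has the second highest number of the three, yet its gap to compound 1 and its gap to compound 2 both lie within the usual scatter, so the three numbers read as equal.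

Compound 4, `O=c1c2sc(-c3ccc(Cl)cc3)cc2ncn1-c1ccc2sc(CN3CCCCC3)cc2c1`, differs from compound 3 by piperidin-1-yl in place of pyrrolidin-1-yl on a saturated chain carbon bound to an aromatic carbon. Among the measured compounds shown here, no pair of measured compounds shows this change on its own. Compound 1 carries the entering ring and compound 2 the leaving ring, each on a different core, and their numbers sit within the scatter of each other, which points to no step beyond the scatter in this assay.

Compound 4 is therefore expected to give about 0.8 nM, within 0.35 nM to 1.9 nM. The expected step from compound 3 to compound 4 is a 1.1-fold lower number from compound 3 to compound 4 (0.06 log units; within the scatter).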

Compound 4, half-maximal inhibitory concentration: 2 nM
The estimate for compound 4 lay 2.5-fold (0.40 log units) below the measured number; measured number above the stated range.
By their numbers in this assay, from the lowest: compounds 1, 3, 2 and 4 (each within the scatter of the next, the first and the last beyond it).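

In this assay, piperidin-1-yl in place of pyrrolidin-1-yl on a saturated chain carbon bound to an aromatic carbon gives a 2.2-fold higher number from compound 3 to compound 4 (0.34 log units; beyond the scatter) and so modestly weaker inhibition. This place on the shared core therefore distinguishes a six-membered ring from a five-membered one, which compound 1 and compound 2 could not show because they differ in more than this ring. Nothing measured here explains the step.

As far as these compounds go, whether the step would carry over to other cores remains open. So does how dimethylamino or morpholin-4-yl would read at this place.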